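Working notes: bromo replaced by 6-fluoropyridin-3-yl on shared core

The compounds below may be only part of what the source reports. "The series", "measured", "known", "first", "only" and "open" are said of these compounds alone.

For the measured compounds named here, compound 2 `COc1cc(OC)c2c(=O)cc(-c3ccc(Br)cc3)oc2c1` gives 12% in a functional assay (Homo sapiens) for antiproliferative activity, read by resazurin assay, with a stated time of 48 h, tested at 5 uM (on this read-out higher numbers stand for a stronger effect at the one concentration tested and lower numbers for a weaker effect), the highest of the two numbers measured so far. The nearest is compound 1 `COc1cc(OC)c2c(=O)cc(-c3ccc(OCCN4CCCC4=O)cc3)oc2c1`, which in this assay gives 7%; the step of a number 5 percentage points higher from compound 1 to compound 2 (within the scatter) lies within the scatter, so the two compounds cannot be ordered. Compound 3 `COc1cc(OC)c2c(=O)cc(-c3ccc(-c4ccc(F)nc4)cc3)oc2c1` is not yet measured and differs from compound 2 in one place: 6-fluoropyridin-3-yl in place of bromo on an aromatic carbon. Going by the values given here, the single measured step, a number 5 percentage points higher from compound 1 to compound 2 (within the scatter), is the only one that touches the same carbon, but it exchanges a chain for a halogen and says nothing about a ring entering there, so it gives little guidance. Both measured numbers are low, and the expected step of a number 3 percentage points higher from compound 2 to compound 3 (within the scatter) is therefore set within the scatter. Compound 3 is estimated at 15%, with a range from 0% to 40%.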

Compound 3, a percentage reported as inhibition, at one concentration (the size of the read-out at that concentration, not a potency): "not active" (no number reported)
Nothing numeric was reported for compound 3, and the estimate cannot be compared.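

In this assay compound 3 is recorded as "not active" with no number, so no step can be read between compound 2 and compound 3. No supporting data bear on this result. The compounds shown leave open how a ring at this aromatic carbon affects the read-out.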